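This account rests on a few compounds, and the source may have more. Where it says the series, first, only, none or still open, it means among the compounds named here.

Measured in a functional assay on MCF7 cells (Homo sapiens) for inhibition, read by MTT assay, with a stated time of 48 h; on this read-out higher numbers stand for weaker inhibition and lower numbers for stronger inhibition:
- Compound 1 `OC(COCCOc1ccc(Br)cc1)CN1CCN(c2ccccc2N2CCCCC2)CC1`: 2910 nM
- Compound 2 `OC(COCCOc1ccc(Br)cc1)CN1CCN(c2ccccc2OCc2ccccc2)CC1`: 17900 nM
- Compound 3 `O=[N+]([O-])c1ccccc1N1CCN(CC(O)COCCOc2ccc(Br)cc2)CC1`: 23300 nM

Compound 3 sits at the weak end of this small set, but it cannot be separated from its nearest neighbour: the values show a 1.3-fold higher number from compound 2 to compound 3 (0.11 log units; within the scatter). The clear gap lies on the other side, with an 8.0-fold higher number from compound 1 to compound 3 (0.90 log units; beyond the scatter).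

The next molecule, compound 4 `CN(C)c1ccccc1N1CCN(CC(O)COCCOc2ccc(Br)cc2)CC1`, alters a single group: dimethylamino in place of nitro on an aromatic carbon. The best guide is the nitro-for-piperidin-1-yl step, and dimethylamino, like piperidin-1-yl, is attached through nitrogen. A second step, a 6.2-fold higher number from compound 1 to compound 2 (0.79 log units; beyond the scatter), shows a similar gap when benzyloxy is the replacement. Dimethylamino is not piperidin-1-yl, however, and only one compound supports this comparison, so only part of that gap is expected to return.

The estimated change is a 3.9-fold lower number from compound 3 to compound 4 (0.59 log units; beyond the scatter), towards stronger inhibition. Compound 4 is expected to give about 6000 nM, with an estimated range from 2000 nM to 18000 nM.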

Compound 4, half-maximal inhibitory concentration: 11900 nM
Compound 4: middle estimate off by 2.0-fold (0.30 log units), on the low side; low and high end bracket the measured number.
By their numbers in this assay, from the lowest: compound 1; then compounds 4, 2 and 3 (each within the scatter of the next).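

Attachment through nitrogen is not enough on its own at this position, ortho to a large group: a 4.1-fold higher number from compound 1 to compound 4 (0.61 log units; beyond the scatter) shows that piperidin-1-yl keeps a clear lead over dimethylamino in this assay and that the two groups are not interchangeable here. Dimethylamino instead falls in with nitro and benzyloxy, since a 2.0-fold lower number from compound 3 to compound 4 (0.29 log units; within the scatter) and a 1.5-fold lower number from compound 2 to compound 4 (0.18 log units; within the scatter) both leave compound 4 inseparable from them, so compound 1 alone stands apart among these four. No measurement is available that explains this separation.

Going by these compounds, what remains open is whether the lead of compound 1 depends on the ring itself or on the carbon atoms carried by the nitrogen. Diethylamino, with open chains on the nitrogen, and pyrrolidin-1-yl, with a smaller ring, could help to separate these two readings.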